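The source may report more compounds than this note shows. Statements on the series, on what has been measured and on what is new or still open speak of the compounds shown alone.

In an assay on cells for inhibition of histone-lysine N-methyltransferase EZH2 (Homo sapiens), read by ELISA, with a stated time of 72 h (on this read-out lower numbers stand for stronger inhibition and higher numbers for weaker inhibition), compound 1 `Cc1cc(C)c(CN2CCc3c(Cl)cc([C@@H](CO)[C@@H]4CCOC4)c(Cl)c3C2=O)c(=O)[nH]1` gives 2910 nM, and compound 2 `Cc1cc(C)c(CN2CCc3c(Cl)cc([C@@H](CO)[C@@H]4CCCO4)c(Cl)c3C2=O)c(=O)[nH]1` gives 1570 nM; the move a 1.9-fold lower number from compound 1 to compound 2 (0.27 log units; within the scatter) is too small to separate the two, so compound 2 and compound 1 stand together on these numbers. Compound 3 `COC(c1cc(Cl)c2c(c1Cl)C(=O)N(Cc1c(C)cc(C)[nH]c1=O)CC2)C1CCN(C(C)=O)CC1` has been measured more than once in this assay, giving 2000 nM; 11 nM (2 entries), and that spread (the several entries of compound 3 in this assay, 2000 nM; 11 nM (2 entries)) shows how far repeated readings can wander here. Compound 4 `Cc1cc(C)c(CN2CCc3c(Cl)cc([C@@H](CO)[C@H]4CCCO4)c(Cl)c3C2=O)c(=O)[nH]1` differs from compound 2 only in configuration: the two compounds have the same atoms and bonds and differ only in configuration as drawn: 1 of 2 stereo elements differ; a stereocentre at a saturated ring carbon is drawn S in compound 2 and R in compound 4. Among the measured compounds shown here, no measured step involves a change of configuration, so the single measured step offers no direction for this one. The step of a 1.0-fold higher number from compound 2 to compound 4 (0.01 log units; within the scatter) is therefore expected to be small, with no clear direction. The estimate for compound 4 is 1600 nM, within a range from 400 nM to 6500 nM.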

Compound 4, half-maximal inhibitory concentration: 1020 nM
For compound 4 the middle estimate is 1.6-fold (0.20 log units) above the measured one; the measured number falls inside the stated range.
By their numbers in this assay, from the lowest: compounds 4, 2 and 1 (each within the scatter of the next, the first and the last beyond it).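

Changing only the configuration at the saturated ring carbon gives a 1.5-fold lower number from compound 2 to compound 4 (0.19 log units; within the scatter), so the two drawn forms cannot be told apart on these numbers. Oxolan-2-yl in place of oxolan-3-yl gives a 2.9-fold lower number from compound 1 to compound 4 (0.46 log units; beyond the scatter), the first step here to pass the scatter, though only modestly. Such a small gap deserves caution, since repeated readings can differ widely: the several entries of compound 3 in this assay, 2000 nM; 11 nM (2 entries)

From the compounds shown here alone, the effect of reversing the other stereocentre remains open. So does whether a carboxylic acid or an amine in place of the oxolan-2-yl group would shift the number further.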